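Series notes: aryl exchange on the vinyl carbon of compound 1

The source may report more compounds than this note shows. Statements on the series, on what has been measured and on what is new or still open speak of the compounds shown alone.

Compound 1 `COc1ccc(/C=C(/SCc2ccc(Cl)cc2)C(=O)c2ccc(Br)cc2)cc1O` is measured in a functional assay on DU-145 cells (Homo sapiens) for inhibition, read by trypan blue exclusion, with a stated time of 96 h (a higher number here means a weaker inhibitor of growth, a lower number a stronger inhibitor of growth), at 1000 nM. Compound 2 `O=C(/C(=C\c1cc(I)c(O)c(I)c1)SCc1ccc(Br)cc1)c1ccc(Br)cc1` gives 1000 nM and compound 3 `COc1ccc(/C=C(/SCc2ccc(F)cc2)C(=O)c2ccc(Br)cc2)cc1O` gives 1000 nM, so compound 1 stands level with both at the digits shown, with neither separated from it beyond the scatter. Among the measured compounds shown here, the only single-point step measured so far, no change at the digits printed from compound 1 to compound 3 (within the scatter), shows that the benzylic aryl halogen is exchanged without effect.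

The unmeasured compound 4 `CN(C)c1ccc(/C=C(/SCc2ccc(Cl)cc2)C(=O)c2ccc(Br)cc2)cc1` differs from compound 1 by 4-(dimethylamino)phenyl in place of 3-hydroxy-4-methoxyphenyl on a double-bonded chain carbon bound to a double-bonded chain carbon. For the measured compounds named here, no measured step touches this position directly. Compound 2 carries a different aryl there than compound 1, and the two values are level, which is the only indication available that variation on this vinyl carbon passes without a visible shift. The expectation for compound 4 is therefore a step of no change at the digits printed from compound 1 to compound 4 (within the scatter), that is none beyond the scatter, in this assay. Compound 4 is estimated at 1000 nM, with a range from 350 nM to 3000 nM.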

Compound 4, concentration for 50% growth inhibition: 10000 nM
Beside the measured number, compound 4's estimate is 10-fold (1.00 log units) below it; the measured number lies above the stated range.
By their numbers in this assay, from the lowest: compounds 1, 2 and 3 (each within the scatter of the next); then compound 4.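

In this assay, the aryl on the double-bonded chain carbon proves sensitive to exchange: 4-(dimethylamino)phenyl in place of 3-hydroxy-4-methoxyphenyl gives a 10-fold higher number from compound 1 to compound 4 (1.00 log units; beyond the scatter). The earlier single-place step, fluoro in place of chloro on an aromatic carbon, showed no change at the digits printed from compound 1 to compound 3 (within the scatter) and gave no sign of such a shift. The hydroxy and methoxy groups leave together as the dimethylamino group enters, so this one step cannot assign the shift to any one of them, and no evidence on its cause is available.

Open is which part of 3-hydroxy-4-methoxyphenyl counts at this place, since no compound shown has an aryl there carrying only the hydroxy or only the methoxy. Also open, on these data alone, is how a plain phenyl, or a phenyl bearing a primary amine or a carboxylic acid, would read on the core of compound 1.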